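Pyrimidine carboxamides: carbamoyl to cyclohexyl ester

The source may hold more compounds than are shown below. What is called first, only, known or untested is meant among the compounds shown, and "the series" means these compounds.

Measured compounds:
compound 1 `O=C(Nc1cc(Cl)cc(Cl)c1)c1cnc(O)nc1C(F)(F)F` — > 10000 nM, a limit of the assay
compound 2 `Cc1ccc(NC(=O)c2cnc(Cl)nc2C(F)(F)F)s1` — 2300 nM
compound 3 `NC(=O)c1cc(NC(=O)c2cnc(Cl)nc2C(F)(F)F)cc(C(F)(F)F)c1` — 5000 nM

In an assay on Jurkat cells for inhibition of nuclear factor NF-kappa-B p105 subunit (Homo sapiens) (a lower number here means a stronger inhibitor, a higher number a weaker inhibitor), compound 3 holds the highest of the two numbers shown; the nearest number, that of compound 2, is lower by a margin beyond the scatter. For compound 1 the result is only (the limit of > 10000 nM in this assay, at which 1 of the 3 values shown sits). Among the measured compounds shown here, no step between measured compounds that differ in a single place is available.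

Compound 4 `O=C(OC1CCCCC1)c1cc(NC(=O)c2cnc(Cl)nc2C(F)(F)F)cc(C(F)(F)F)c1` is not yet measured. It differs from compound 3 as cyclohexyloxy in place of amino on a carbonyl carbon. For the measured compounds named here, with no measured step of this kind to lean on, the expected step of a 1.1-fold lower number from compound 3 to compound 4 (0.05 log units; within the scatter) is small, of uncertain direction, and need not exceed the scatter. For compound 4 the estimate is 4500 nM, with a range from 1500 nM to 15000 nM.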

Compound 4, half-maximal inhibitory concentration: 1800 nM
Compound 4: middle estimate off by 2.5-fold (0.40 log units), on the high side; the range from low to high includes it.
By their numbers in this assay, from the lowest: compounds 4 and 2 (each within the scatter of the next); then compound 3. At a limit, above all of these: compound 1.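

In this assay the carbonyl carbon takes a much larger group than amino with no loss: cyclohexyloxy in its place gives a modest gain beyond the scatter (a 2.8-fold lower number from compound 3 to compound 4 (0.44 log units; beyond the scatter)). The hydrogen-bond donor of the amino group is therefore not needed at this place for the inhibition seen in compound 4. No measured property bears on this step.

As far as these compounds go, whether the gain belongs to the cyclohexane ring or to the ester oxygen remains open. A methyl ester, a cyclohexyl amide or the carboxylic acid on this carbonyl carbon would separate the two.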